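A few compounds are considered here, and "the series" means these few. Any claim that something is new, unique, unknown or untested is made for them only; others in the source may bear on it.

Measured compounds:
compound 1 `CCCOC(=O)C1=C(C)NC(=O)NC1c1ccsc1` — 6%
compound 2 `CC1=C(C(=O)NC(C)C)C(c2ccsc2)NC(=O)N1` — 1%

In an assay on membranes from HeLa cells for displacement of a labelled ligand from adenosine receptor A3 (Homo sapiens), read by scintillation counting, with a stated time of 180 min, tested at 1 uM (a higher number here means more inhibition at the concentration tested (going by the name of the read-out), a lower number less inhibition), compound 1 gives 6% and compound 2 gives 1%. The two numbers lie within the usual scatter of each other, so compound 2 cannot be placed above or below compound 1 on these figures; both sit near the floor of the read-out. For the measured compounds named here, the single step between them, a number 5 percentage points lower from compound 1 to compound 2 (within the scatter), is the only measured step in the set.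

Compound 3 `CCC(CC)OC(=O)C1=C(C)NC(=O)NC1c1ccsc1` differs from compound 2 by (pentan-3-yl)oxy in place of isopropylamino on a carbonyl carbon. The change runs back toward the ester type of compound 1, with a larger alkyl group on the oxygen. Going by the values given here, the one step on record, the change from compound 1 to compound 2, stayed within the scatter, and no other change of this place has been measured. In this assay no step beyond the scatter is therefore expected. Compound 3 is estimated at 5%, within -5% to 15%. The expected step is a number 4 percentage points higher from compound 2 to compound 3 (within the scatter).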

Compound 3, a percentage reported as inhibition, at one concentration (the size of the read-out at that concentration, not a potency): 6%
The estimate for compound 3 lay 1 percentage points below the measured number; measured number inside the range.
By their numbers in this assay, from the lowest: compounds 2, 1 and 3 (each within the scatter of the next).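

In this assay, (pentan-3-yl)oxy in place of isopropylamino on the carbonyl carbon gives a number 5 percentage points higher from compound 2 to compound 3 (within the scatter), so returning to an ester with a larger alkyl group on the oxygen separates neither type of group from the other. Against the propoxy ester, ethyl in place of hydrogen on the saturated chain carbon bound to the oxygen gives no change at the digits printed from compound 1 to compound 3 (within the scatter), which shows that this enlargement of the ester group does not move the figure outside the scatter. No measurement on record bears on why all these figures lie near the floor of the read-out.

As far as these compounds go, whether a carboxylic acid, a primary amine or a longer chain such as octyloxy on this carbonyl carbon would give a step beyond the scatter stays open. For the compounds shown here, with every step so far inside the scatter, no group at this place can yet be ranked above another.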